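The source may report more compounds than this note shows. Statements on the series, on what has been measured and on what is new or still open speak of the compounds shown alone.

Two compounds of the series have numbers in a functional assay on HepG2 cells (Homo sapiens) for antiproliferative activity, read by MTT assay, with a stated time of 48 h; a higher number here means a weaker inhibitor, a lower number a stronger inhibitor: compound 1 `Cc1ccc(-c2nc(NN)c3cc(Cl)ccc3n2)cc1` gives 4.17 ug/mL, and compound 2 `Cc1ccc(-c2nc(SCC#N)c3cc(Cl)ccc3n2)cc1` gives 4.37 ug/mL. Among the compounds with values here, compound 2 stands with compound 1 inside the scatter, as the single measured step, a 1.0-fold higher number from compound 1 to compound 2 (0.02 log units; within the scatter), shows. Compound 3 `C=CCSc1nc(-c2ccc(C)cc2)nc2ccc(Cl)cc12` differs from compound 2 by vinyl in place of cyano on a saturated chain carbon bound to a sulfur. That measured step replaces the whole substituent on the aromatic carbon and does not touch the chain on the sulfur, so it gives no direction for this change, and nothing beyond the scatter is expected in this assay. For compound 3 the estimate is 4.5 ug/mL, with a range from 2.2 ug/mL to 9 ug/mL, which is expected to mean a 1.0-fold higher number from compound 2 to compound 3 (0.01 log units; within the scatter).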

Compound 3, half-maximal inhibitory concentration: 23.9 ug/mL
Estimate against measurement, compound 3: 5.3-fold (0.73 log units) below, and the stated range ends below it.
By their numbers in this assay, from the lowest: compounds 1 and 2 (each within the scatter of the next); then compound 3.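

On the saturated chain carbon bound to a sulfur, the group matters in this assay: vinyl in place of cyano gives a 5.5-fold higher number from compound 2 to compound 3 (0.74 log units; beyond the scatter) and so separates two close thioether side chains. The same separation appears against the hydrazine-type substituent, with a 5.7-fold higher number from compound 1 to compound 3 (0.76 log units; beyond the scatter) for allylsulfanyl in place of aminoamino on an aromatic carbon, although compound 1 and compound 2 lay within the scatter. No supporting data bear on the reason for this step.

Open, going by these compounds, is whether a carboxylic acid or an amine in place of cyano would stay within the scatter of compound 2 or follow compound 3. On these data alone, a longer chain on the sulfur is equally open.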